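The source may hold more compounds than are shown below. What is called first, only, known or untested is meant among the compounds shown, and "the series" means these compounds.

Compound 1 `CCN(Cc1ccccc1)C(=O)C1CCN(S(=O)(=O)c2ccccc2)CC1` carries a plain phenyl on the sulfonyl sulfur; in a functional assay on CHO cells for positive allosteric modulation of muscarinic acetylcholine receptor M5 (Homo sapiens), read by calcium flux (a higher number here means a larger maximal response, a lower number a smaller maximal response), compound 1 gives 69% as its maximal response. Compound 2 `CCN(Cc1ccccc1)C(=O)C1CCN(S(=O)(=O)c2c(C)noc2C)CC1` and compound 3 `CCN(Cc1ccccc1)C(=O)C1CCN(S(=O)(=O)c2ccccn2)CC1` share the core of compound 1 and differ only in the group on that sulfur, but for neither compound was a result reported in this assay: the entry for compound 2 reads "not determined" (no result reported) and the entry for compound 3 reads "not determined" (no result reported), so compound 3 stands without a single number, and a second entry shares that gap. Compound 4 `CCN(Cc1ccccc1)C(=O)C1CCN(S(=O)(=O)c2ccc3nsnc3c2)CC1` differs from compound 3 in one place: a group of 9 heavy atoms (6 carbon, 2 nitrogen, 1 sulfur; one five-membered aromatic ring with 3 hetero atoms, one six-membered aromatic ring of carbon only) in place of a group of 6 heavy atoms (5 carbon, 1 nitrogen; one six-membered aromatic ring with 1 hetero atom), on a sulfonyl sulfur. Going by the values given here, with no measured step anywhere in this set, no direction can be read for this change; the only anchor is the maximal response of compound 1. Compound 4 is therefore expected to reach about 65% in this assay, within a broad range from 35% to 95%.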

Compound 4, largest response reached (reported as percent of maximum), in percent of the reference or control that the assay uses: 81%
For compound 4 the middle estimate is 16 percentage points below the measured one; measured number inside the range.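

At the sulfonyl sulfur, this assay now shows a first readable change, a number 12 percentage points higher from compound 1 to compound 4 (beyond the scatter), so this position accepts a two-ring group with nitrogen and sulfur in place of plain phenyl without losing maximal response. Steps to compound 2 or compound 3 cannot be read, as neither has a number. Nothing measured here accounts for the rise. Still open, from the compounds shown here alone, is whether the second ring or the hetero atoms carry the change, and how a phenyl bearing a methoxy group or a carboxylic acid would respond.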